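Five-Membered Ring Swaps on a Shared Core

The source may report more compounds than this note shows. Statements on the series, on what has been measured and on what is new or still open speak of the compounds shown alone.

Of the compounds shown here, three built on one shared core have been tested in an assay on CHO cells for displacement of a labelled ligand from adenosine receptor A3 (Homo sapiens), read by scintillation counting, tested at 10 uM; on this read-out lower numbers stand for less inhibition and higher numbers for more inhibition at the one concentration tested (going by the name of the read-out). Compound 1 `CC(C)(C)Cc1c(-c2ccoc2)sc(N)c1C(=O)c1ccc(Cl)cc1` gives 1%. Compound 2 `CC(C)c1ccc(-c2sc(N)c(C(=O)c3ccc(Cl)cc3)c2CC(C)(C)C)cc1`, which carries a 4-isopropylphenyl in place of the furan-3-yl, gives 1%. Compound 3 `CC(C)(C)Cc1c(-c2cn[nH]c2)sc(N)c1C(=O)c1ccc(Cl)cc1`, which carries a 1H-pyrazol-4-yl at that same place, gives 1%. The step of no change at the digits printed from compound 1 to compound 2 (within the scatter) and the step of no change at the digits printed from compound 1 to compound 3 (within the scatter) both lie within the scatter, and so does no change at the digits printed from compound 2 to compound 3 (within the scatter). Compound 3 therefore stands level with compounds 1 and 2, and none of the three shows inhibition worth noting at the single concentration tested.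

Compound 4 `CC(C)(C)Cc1c(-c2ccsc2)sc(N)c1C(=O)c1ccc(Cl)cc1` has not yet been measured. It differs from compound 3 in one place: thiophen-3-yl in place of 1H-pyrazol-4-yl on an aromatic carbon This is once more a swap of one small aromatic ring at the same position on the core. The three measured steps are the ones that bear on it, and all were flat: furan-3-yl, 4-isopropylphenyl and 1H-pyrazol-4-yl at this position gave no movement beyond the scatter. No movement beyond the scatter is expected in this assay here either. Compound 4 is therefore expected to give 2%, within a range from -5% to 12%, which means an expected step of a number 1 percentage points higher from compound 3 to compound 4 (within the scatter).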

Compound 4, a percentage reported as inhibition, at one concentration (the size of the read-out at that concentration, not a potency): 4%
For compound 4 the middle estimate is 2 percentage points below the measured one, within the range that was stated.
By their numbers in this assay, from the lowest: compounds 1, 2, 3 and 4 (each within the scatter of the next).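

Placing thiophen-3-yl on this aromatic carbon gives a number 3 percentage points higher from compound 3 to compound 4 (within the scatter) and a number 3 percentage points higher from compound 2 to compound 4 (within the scatter) and also a number 3 percentage points higher from compound 1 to compound 4 (within the scatter) in this assay at the one concentration tested. This is the first ring at this place to bring in a sulfur atom, and exchanging 1H-pyrazol-4-yl, with 1 hydrogen-bond donor, for thiophen-3-yl, with 0 hydrogen-bond donors, still produces no step beyond the scatter, so all four groups shown here sit together and none goes against that flat picture. No outside measurement is available to explain this flatness.

With every value this small, the compounds shown leave open whether anything placed on this carbon can raise the read-out at all, for instance an aminomethyl group, a carboxylic acid or a longer alkyl chain. They also leave open whether replacing the neopentyl group, which stays the same in all four compounds, with a smaller chain such as ethyl or with a primary amine would change the number, and whether the ring swaps would then still make no difference.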